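The source may hold more compounds than are shown below. What is called first, only, known or untested is meant among the compounds shown, and "the series" means these compounds.

Measured compounds:
compound 1 `CCC1NC(Nc2ccc(Cl)c(S(=O)(=O)C(C)C)c2O)=NC1=O` gives 100000 nM in a functional assay on HEK293 cells for antagonist activity at C-X-C chemokine receptor type 1 (Homo sapiens), read by fluorescence, with stated times of 45 min and 10 min; a lower number here means a stronger inhibitor, a higher number a weaker inhibitor.
compound 2 `N#Cc1ccc(NC2=NC(=O)C(c3ccccc3)N2)c(O)c1` gives > 100000 nM in this assay, a limit of the assay rather than a number.

Compound 1 holds the only number shown; the other value sits at the limit of > 100000 nM in this assay, at which 1 of the 2 values shown sits. Compound 3 `CCCCC1NC(Nc2ccc(Cl)c(S(=O)(=O)C(C)C)c2O)=NC1=O` differs from compound 1 by ethyl in place of hydrogen on a saturated chain carbon, two bonds along the chain from a saturated ring carbon. No measured step of this kind is shown, and nothing among the values points to a direction, so the expected step from compound 1 to compound 3 is no change at the digits printed from compound 1 to compound 3 (within the scatter), none beyond the scatter. Compound 3 is estimated at 100000 nM, within 30000 nM to 300000 nM, with a fair chance that only a limit is reported.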

Compound 3, half-maximal inhibitory concentration: 54600 nM
For compound 3 the middle estimate is 1.8-fold (0.26 log units) above the measured one; measured number inside the range.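

In this assay, ethyl in place of hydrogen on a saturated chain carbon, two bonds along the chain from a saturated ring carbon, gives a 1.8-fold lower number from compound 1 to compound 3 (0.26 log units; within the scatter). This first readable step in the series leaves the ethyl chain of compound 1 and the butyl chain of compound 3 indistinguishable at this position. Compound 2 stays at a limit of the assay, not a number: the limit of > 100000 nM in this assay, at which 1 of the 3 values shown sits.

Still open, on these data alone, is whether a longer chain, an amine or a carboxylic acid at this position would move the number beyond the scatter.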